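Diol Side Chain Replacing Methylcarbamoyl in Compound 4

This account rests on a few compounds, and the source may have more. Where it says the series, first, only, none or still open, it means among the compounds named here.

Measured compounds:
compound 1, `Cn1ncc(Cl)c1-c1cc(C(=O)N[C@@H]2CN[C@H](CCO)C[C@H]2c2ccc(F)c(F)c2)oc1Cl`, 0.98 nM
compound 2, `CC(=O)OCC[C@@H]1C[C@@H](c2ccc(F)c(F)c2)[C@H](NC(=O)c2cc(-c3c(Cl)cnn3C)c(Cl)o2)CN1`, 3.4 nM
compound 3, `CNC(=O)C[C@@H]1C[C@@H](c2ccc(F)c(F)c2)[C@H](NC(=O)c2cc(-c3c(Cl)cnn3C)c(Cl)o2)CN1`, 1.37 nM

All three share one core and differ only in the side chain on the saturated ring. In an assay for inhibition of RAC-alpha serine/threonine-protein kinase (Homo sapiens), read by HTRF, with a stated time of 1 h (a lower number here means a stronger inhibitor, a higher number a weaker inhibitor), compound 3 stands second highest of the three numbers: its nearest neighbour is compound 1, with a 1.4-fold higher number from compound 1 to compound 3 (0.15 log units; within the scatter), and its furthest is compound 2, with a 2.5-fold lower number from compound 2 to compound 3 (0.39 log units; beyond the scatter).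

Compound 4, `Cn1ncc(Cl)c1-c1cc(C(=O)N[C@@H]2CN[C@H](CC(O)CO)C[C@H]2c2ccc(F)c(F)c2)oc1Cl`, is not yet measured. It differs from compound 3 by 1,2-dihydroxyethyl in place of methylcarbamoyl on a saturated chain carbon bound to a saturated ring carbon.

Within the data shown here, two measured steps bear on this. The change from hydroxymethyl to methylcarbamoyl, a 1.4-fold higher number from compound 1 to compound 3 (0.15 log units; within the scatter), lay within the scatter, so a hydroxyl-bearing chain and the methylcarbamoyl chain gave much the same number. The acetoxymethyl to methylcarbamoyl step, a 2.5-fold lower number from compound 2 to compound 3 (0.39 log units; beyond the scatter), was modest. The new 1,2-dihydroxyethyl group brings back free hydroxyls, so the number for compound 4 is expected to sit near compounds 1 and 3, with no step beyond the scatter in this assay.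

The estimated step is a 1.1-fold higher number from compound 3 to compound 4 (0.04 log units; within the scatter). Compound 4 is therefore estimated at 1.5 nM, within a range from 0.6 nM to 4 nM.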

Compound 4, half-maximal inhibitory concentration: 3.31 nM
For compound 4 the middle estimate is 2.2-fold (0.34 log units) below the measured one; the range from low to high includes it.
By their numbers in this assay, from the lowest: compounds 1 and 3 (each within the scatter of the next); then compounds 4 and 2 (each within the scatter of the next).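

In this assay, a hydroxymethyl added to the chain of compound 1 costs something rather than gains (a 3.4-fold higher number from compound 1 to compound 4 (0.53 log units; beyond the scatter)), and 1,2-dihydroxyethyl in place of methylcarbamoyl does much the same (a 2.4-fold higher number from compound 3 to compound 4 (0.38 log units; beyond the scatter)). The earlier near-match between a hydroxyl-bearing chain and the methylcarbamoyl chain therefore does not extend to every chain with free hydroxyls, and this position does respond, if only modestly, to what the chain carries at its end. The diol also stands level with the acetate ester of compound 2 (a 1.0-fold lower number from compound 2 to compound 4 (0.01 log units; within the scatter)), so a chain with free hydroxyls and one with its hydroxyl capped can give the same number, and free hydroxyls alone do not set the number here.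

Nothing measured here accounts for these steps. The compounds shown leave open how this position would respond to a chain ending in an amine or a carboxylic acid, and whether a longer chain carrying a single hydroxyl would stay as close to compound 1 as the methylcarbamoyl chain of compound 3 does.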